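The compounds below may be only part of what the source reports. "The series", "measured", "known", "first", "only" and "open" are said of these compounds alone.

Three compounds built on one shared core were examined in an ADME assay on HepG2 cells (Homo sapiens) for cytotoxicity, read by luminescence, with a stated time of 72 h; a lower number here means that less compound is needed, a higher number that more compound is needed for the effect. Compound 1 `CCCOc1cccc(-c2[nH]c3cc(OC)ccc3c(=O)c2C(=O)OCC)c1` returns only a limit in this assay, namely > 21500 nM. Compound 2 `CCOC(=O)c1c(-c2cccc(OCC(C)C)c2)[nH]c2cc(OC)ccc2c1=O` likewise gives only a limit in this assay, > 21500 nM. Compound 3 `CCOC(=O)c1c(-c2cccc(OC(F)(F)F)c2)[nH]c2cc(OC)ccc2c1=O` also gives only a limit in this assay, > 21500 nM. Where compound 3 stands among the other two therefore cannot be read from the numbers. The steps joining them, a step that the two limits leave unreadable from compound 1 to compound 2, a step that the two limits leave unreadable from compound 1 to compound 3 and a step that the two limits leave unreadable from compound 2 to compound 3, are all of unreadable size because of the limit of > 21500 nM in this assay, at which 3 of the 3 values shown sit.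

Compound 4 `CCOC(=O)c1c(-c2cccc(O)c2)[nH]c2cc(OC)ccc2c1=O` differs from compound 3 by hydrogen in place of trifluoromethyl on an oxygen on an aromatic ring. Going by the values given here, no measured step covers this exchange, and the three known steps, all unreadable, give no guide to its size or direction. The account therefore expects no step beyond the scatter in this assay, with a step that the limit leaves unreadable from compound 3 to compound 4 as the expected change. Compound 4 is expected to give 30000 nM in this assay, within a range from 12000 nM to 100000 nM, and most likely to be reported again only as a limit.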

Compound 4, half-maximal effective concentration: > 21500 nM
Compound 4 gave a limit, no number; the forecaster's own chance of this, stated with the estimate: 80%; the middle value is on the limit's open side.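

Compound 4 also returns only a limit in this assay, and its steps to compound 1, compound 2 and compound 3 cannot be read, because all the values share one limit: the limit of > 21500 nM in this assay, at which 4 of the 4 values shown sit.

The compounds shown leave open whether the group on the oxygen affects the result in this assay at all.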